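Stereocentre left undrawn: compound 2 to compound 3

The compounds below may be only part of what the source reports. "The series", "measured", "known", "first", "only" and "open" are said of these compounds alone.

Two compounds of this series have numbers in a functional assay on cells for agonist activity at Free fatty acid receptor 1 (Homo sapiens), read by calcium flux; a higher number here means that more compound is needed for the effect, a lower number that less compound is needed. Compound 1, `Cc1cccc(C)c1-c1cccc(OCn2cc(CCC(=O)O)nn2)c1`, gives 32200 nM. Compound 2, `CCO[C@@H](CC(=O)O)c1ccc(OCc2cccc(-c3c(C)cccc3C)c2)s1`, gives 40100 nM, and this value sits within the usual scatter of the value of compound 1, so the two compounds are not separated by the numbers shown.

Compound 3, `CCOC(CC(=O)O)c1ccc(OCc2cccc(-c3c(C)cccc3C)c2)s1`, is not yet measured. The change from compound 2 to compound 3 is the two compounds have the same atoms and bonds; at least one stereo element is drawn with a configuration in one of them and without one in the other: 1 of 1 stereo elements differ; a stereocentre at a saturated chain carbon is drawn S in compound 2 and without a configuration in compound 3. Going by the values given here, no step between two measured compounds of this kind is available here, so the expectation rests on the structural change alone: a stereocentre drawn in one compound and left without configuration in the other would be expected to give a step that is small, toward a somewhat higher number or none beyond the scatter, as a 1.2-fold higher number from compound 2 to compound 3 (0.10 log units; within the scatter).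

Compound 3 is therefore expected in this assay at about 50000 nM, with a range of 22000 nM to 120000 nM.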

Compound 3, half-maximal effective concentration: 57 nM
Compound 3: middle estimate off by 880-fold (2.94 log units), on the high side, and the stated range ends above it.
By their numbers in this assay, from the lowest: compound 3; then compounds 1 and 2 (each within the scatter of the next).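

In this assay, the drawing of one stereocentre at a saturated chain carbon goes with a 700-fold lower number from compound 2 to compound 3 (2.85 log units; beyond the scatter), a large step beyond the scatter. Compounds 1 and 2 were not separated by their numbers, so they gave no sign that this series can reach a far lower number or that this carbon carries so much weight. The pair offers only one structural difference to set against the step: the fact that one of compounds 2 and 3 is drawn with a defined configuration and the other without, at the place where they differ.

The compounds shown leave open what compound 3 holds at this carbon, whether a single form or a mixture, and a counterpart drawn R would show whether the lower number belongs to that configuration. They also leave open how a methoxy group or a longer ether chain on this carbon would read.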